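Notes on a ring-carbon stereocentre change in the series

The source may report more compounds than this note shows. Statements on the series, on what has been measured and on what is new or still open speak of the compounds shown alone.

Measured so far in an ADME assay on Caco-2 cells (Homo sapiens) for permeability, in the apical to basolateral direction, at pH 7.4; a lower number here means that the compound crosses the layer more slowly, a higher number that the compound crosses the layer faster:
- compound 1 (`Cc1ccc2[nH]c(C(=O)N[C@H]3CN(S(=O)(=O)c4ccccc4)C[C@@H]3C(=O)NC[C@H]3CCCN3)cc2c1`): 0.11 10^-6 cm/s
- compound 2 (`Cc1ccc2[nH]c(C(=O)N[C@H]3CN(S(=O)(=O)c4ccccc4)C[C@@H]3C(=O)N[C@@H]3CCCN(C)C3)cc2c1`): 0.76 10^-6 cm/s

Compound 2 holds the higher of the two values, and the gap to compound 1 lies beyond the usual scatter. Compound 3 (`Cc1ccc2[nH]c(C(=O)N[C@H]3CN(S(=O)(=O)c4ccccc4)C[C@@H]3C(=O)N[C@H]3CCCN(C)C3)cc2c1`) has not yet been measured in this assay. Its relation to compound 2 is this: the two compounds have the same atoms and bonds and differ only in configuration as drawn: 1 of 3 stereo elements differ; a stereocentre at a saturated ring carbon is drawn R in compound 2 and S in compound 3; a stereocentre at a saturated ring carbon is drawn R in compound 2 and S in compound 3.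

Within the data shown here, only one measured step is available (a 6.9-fold higher number from compound 1 to compound 2 (0.84 log units; beyond the scatter)). It puts 1-methylpiperidin-3-yl in place of (pyrrolidin-2-yl)methyl on an amide-type nitrogen, so it replaces a whole group, whereas atoms and bonds stay the same here. Among the measured compounds shown here, no measured pair differs only in configuration, so the data give neither a size nor a direction for this change. No step beyond the scatter is therefore expected in this assay, and the range is kept wide. The expected step is small (a 1.1-fold lower number from compound 2 to compound 3 (0.04 log units; within the scatter)). The estimated value for compound 3 is 0.7 10^-6 cm/s (expected range 0.25 10^-6 cm/s to 1.8 10^-6 cm/s).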

Compound 3, apparent permeability: 0.3 10^-6 cm/s
Compound 3: middle estimate off by 2.3-fold (0.37 log units), on the high side, within the range that was stated.
By their numbers in this assay, from the lowest: compound 1; then compound 3; then compound 2.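

In this assay the configuration at this saturated ring carbon now proves to matter on its own, with a 2.5-fold lower number from compound 2 to compound 3 (0.40 log units; beyond the scatter), a step beyond the scatter that no earlier pair could have shown. With nothing entering or leaving, this shift can be assigned to that one stereocentre, because the rest of the structure is unchanged: the fact that compounds 2 and 3 differ only in the configuration as drawn. The replacement of (pyrrolidin-2-yl)methyl by 1-methylpiperidin-3-yl also keeps its direction in both drawn forms, but its size depends on the configuration, with a 2.7-fold higher number from compound 1 to compound 3 (0.44 log units; beyond the scatter) for the S form against a 6.9-fold higher number from compound 1 to compound 2 (0.84 log units; beyond the scatter) for the R form.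

This ordering of the two forms rests on a single pair, so it remains a statement about the 1-methylpiperidin-3-yl amide alone and not a rule for the series. Whether the R form keeps its lead with 1-ethylpiperidin-3-yl or an unsubstituted piperidin-3-yl on the amide nitrogen stays open, as does the reason for the gap.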